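This account rests on a few compounds, and the source may have more. Where it says the series, first, only, none or still open, it means among the compounds named here.

Measured compounds:
- compound 1, `C1=C(c2cncc(OCc3ccccc3)c2)CC2CNCC1C2` — 44 nM
- compound 2, `Fc1ccc(C2=CC3CNCC(C2)C3)cn1` — 28 nM
- compound 3, `C1=C(c2cnccn2)CC2CNCC1C2` — 828 nM

All three were tested in an in vitro assay on SH-SY5Y cells for displacement of a labelled ligand from Neuronal acetylcholine receptor; alpha3/beta4 (Homo sapiens); on this read-out lower numbers stand for stronger inhibition and higher numbers for weaker inhibition. Compound 1 gives 44 nM, which places it second highest of the three numbers. Its nearest neighbour is compound 2, whose value of 28 nM lies within the usual scatter of compound 1, so no order can be read between the two. Compound 3, at 828 nM, stands far above compound 1, a gap well beyond the scatter.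

The unmeasured compound 4, `Clc1cccc(Oc2cncc(C3=CC4CNCC(C3)C4)c2)c1`, is reached from compound 1 by a single change: 3-chlorophenyl in place of benzyl on an oxygen on an aromatic ring. Both groups carry the same count of heavy atoms and a single six-membered aromatic ring of carbon only; the difference is the chlorine and the loss of the linking carbon.

Going by the values given here, no measured pair shows this kind of exchange, so the expected size of the step in this assay rests only on the two aromatic ether compounds 1 and 2. A change of a 1.5-fold higher number from compound 1 to compound 4 (0.17 log units; within the scatter) is expected, with a somewhat higher number as the more likely direction, but not clearly beyond the scatter. Compound 4 is therefore estimated at 65 nM, with a plausible range from 15 nM to 280 nM.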

Compound 4, inhibition constant: 22 nM
Compound 4: the middle estimate sits 3.0-fold (0.47 log units) above what was measured; the measured number falls inside the stated range.
By their numbers in this assay, from the lowest: compounds 4, 2 and 1 (each within the scatter of the next); then compound 3.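

In this assay, putting 3-chlorophenyl in place of benzyl on the oxygen on the aromatic ring gives a 2.0-fold lower number from compound 1 to compound 4 (0.30 log units; within the scatter), a step that stays within the usual scatter. Going by these compounds alone, this position therefore accepts a group carrying a chlorine and lacking the linking carbon with no difference that can be read, something the earlier compounds, none of which formed a pair differing in one place, could not show. Nothing measured here bears on why the two groups read alike.

From the compounds shown here alone, the exchange makes two alterations at once, so the separate contributions of the chlorine and the linking carbon remain open, and unsubstituted phenyl on the same oxygen would be needed to divide them. Also open, going by these compounds, is how this position responds to a longer chain, such as phenethyl, or to a group carrying an amine or a carboxylic acid.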